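Sec-butoxy for isopropylamino on the carbonyl: expectation

This account rests on a few compounds, and the source may have more. Where it says the series, first, only, none or still open, it means among the compounds named here.

Measured so far:
compound 1 `CCCC(=O)C1=C(C)NC(=O)NC1c1ccsc1` — 9%
compound 2 `CC1=C(C(N)=O)C(c2ccsc2)NC(=O)N1` — 1%
compound 3 `CC1=C(C(=O)NC(C)C)C(c2ccsc2)NC(=O)N1` — 3%

In an assay on membranes from HEK293 cells for displacement of a labelled ligand from adenosine receptor A2b (Homo sapiens), read by scintillation counting, with a stated time of 30 min, tested at 1 uM (a lower number here means less inhibition, a higher number more inhibition at the concentration tested (going by the name of the read-out)), compound 3 stands second of the three numbers, but a number 6 percentage points lower from compound 1 to compound 3 (within the scatter) and a number 2 percentage points higher from compound 2 to compound 3 (within the scatter) both lie within the scatter, so the three compounds cannot be told apart on this read-out; all show little inhibition.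

Compound 4 `CCC(C)OC(=O)C1=C(C)NC(=O)NC1c1ccsc1` is the next step from compound 3: sec-butoxy in place of isopropylamino on a carbonyl carbon. Within the data shown here, the steps that bear on it are those exchanging the group on the same carbonyl carbon, a number 6 percentage points lower from compound 1 to compound 3 (within the scatter) and a number 2 percentage points higher from compound 2 to compound 3 (within the scatter), each within the scatter. In this assay the step expected is therefore a number 2 percentage points higher from compound 3 to compound 4 (within the scatter), none beyond the scatter. Compound 4 is expected to give 5%, between -5% and 15%.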

Compound 4, a percentage reported as inhibition, at one concentration (the size of the read-out at that concentration, not a potency): 39%
The estimate for compound 4 lay 34 percentage points below the measured number, and the stated range ends below it.
By their numbers in this assay, from the lowest: compounds 2, 3 and 1 (each within the scatter of the next); then compound 4.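

Among these compounds, at this carbonyl carbon, sec-butoxy is the first group to lift the number in this assay beyond the scatter, against isopropylamino (a number 36 percentage points higher from compound 3 to compound 4 (beyond the scatter)), amino (a number 38 percentage points higher from compound 2 to compound 4 (beyond the scatter)) and propyl (a number 30 percentage points higher from compound 1 to compound 4 (beyond the scatter)). The position therefore does respond to the group it carries, which the three earlier compounds, all within the scatter of each other, could not show. Nothing at hand accounts for the rise.

From the compounds shown here alone, whether the rise follows the oxygen link or the sec-butyl chain stays open. Ethoxy and sec-butylamino on the same carbonyl carbon would separate the two.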